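The source may report more compounds than this note shows. Statements on the series, on what has been measured and on what is new or still open speak of the compounds shown alone.

Two compounds make up the measured set. Compound 1 `O=C1CSC(c2ccc([N+](=O)[O-])cc2)N1CCN1CCCCC1` and compound 2 `O=C1CSC(c2ccc(F)cc2)N1CCN1CCCCC1` share one core and differ at a single spot on the aromatic ring, where fluoro replaces nitro. In an ADME assay on Vero cells (Chlorocebus sabaeus) for cytotoxicity, read by neutral red uptake, tested at 1575 ug/mL (a lower number here means a stronger effect, a higher number a weaker effect of the compound at the concentration tested), compound 1 gives 15%, and in the same test compound 2 gives 14%. Within the data shown here, the single measured step, a number 1 percentage points lower from compound 1 to compound 2 (within the scatter), is therefore too small to count as a real difference. Compound 2 thus stands next to compound 1, with nothing separating the two beyond the usual scatter.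

Compound 3 `O=C1CSC(c2ccc(Cl)cc2)N1CCN1CCCCC1` is the next member of the series. Its difference from compound 2 is chloro in place of fluoro on an aromatic carbon. Among the measured compounds shown here, the only measured step that bears on this change is the one from compound 1 to compound 2, which also swapped the group at this aromatic carbon and stayed within the scatter. On that basis the expected step in this assay is a number 1 percentage points higher from compound 2 to compound 3 (within the scatter), that is, none beyond the scatter. The estimate for compound 3 in this assay is 15%, with a range from 5% to 28%.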

Compound 3, a percentage reported as activity, at one concentration (the size of the read-out at that concentration, not a potency): 13%
Estimate against measurement, compound 3: 2 percentage points above; the measured number falls inside the stated range.
By their numbers in this assay, from the lowest: compounds 3, 2 and 1 (each within the scatter of the next).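

In this assay chloro in place of fluoro gives a number 1 percentage points lower from compound 2 to compound 3 (within the scatter) and chloro in place of nitro gives a number 2 percentage points lower from compound 1 to compound 3 (within the scatter) on the same aromatic carbon. Before this result only one pair of groups could be compared at this spot, para to a large group; now nitro, fluoro and chloro can all be compared with one another, and none of the three stands apart from the others in this test at its single concentration. No further measurement is available that could explain this flat picture.

All three groups are single substituents without hydrogen-bond donors, so the compounds shown leave open whether an amine, a carboxylic acid or a longer chain on this carbon would produce a step beyond the scatter. They also leave open whether chloro would behave the same way at another carbon of the aromatic ring, and whether changes elsewhere in the shared core would move the number more than any change at this carbon has done so far.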